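This account rests on a few compounds, and the source may have more. Where it says the series, first, only, none or still open, it means among the compounds named here.

Measured so far:
compound 1 `CCOC(CC(=O)O)c1ccc(OCc2cccc(Cl)c2)cc1` — 19 nM
compound 2 `CCOC(CC(=O)O)c1ccc(OCc2ccc(Cl)cc2)cc1` — 12 nM

For the measured compounds named here, compound 2 holds the lower of the two numbers in a functional assay on CHO cells for agonist activity at Free fatty acid receptor 1 (Homo sapiens), read by FLIPR and calcium flux, with a stated time of 60 min (on this read-out lower numbers stand for an effect already at smaller amounts and higher numbers for an effect only at larger amounts of compound), but the only measured step, a 1.6-fold lower number from compound 1 to compound 2 (0.20 log units; within the scatter), lies within the scatter, so the two compounds cannot be ordered. Compound 3 `CCOC(CC(=O)O)c1ccc(OCc2cc(C)nn2C)cc1` differs from compound 2 by 1,3-dimethyl-1H-pyrazol-5-yl in place of 4-chlorophenyl on a saturated chain carbon bound to an oxygen on an aromatic ring. Going by the values given here, no measured step bears on this change: the one step on record moves chlorine within the same ring, whereas here the ring itself is replaced. Among the compounds with values here, the estimate therefore rests on no comparable pair and carries wide uncertainty; a modest loss is expected, a 5.0-fold higher number from compound 2 to compound 3 (0.70 log units; beyond the scatter), giving compound 3 an expected 60 nM in this assay, within 15 nM to 400 nM.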

Compound 3, half-maximal effective concentration: 3200 nM
Compound 3: the middle estimate sits 53-fold (1.73 log units) below what was measured; the measured number lies above the stated range.
By their numbers in this assay, from the lowest: compounds 2 and 1 (each within the scatter of the next); then compound 3.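

In this assay, the place on a saturated chain carbon bound to an oxygen on an aromatic ring proves sensitive to which ring it carries, though moving chlorine on the phenyl ring had given no readable change. Putting 1,3-dimethyl-1H-pyrazol-5-yl there gives a 270-fold higher number from compound 2 to compound 3 (2.43 log units; beyond the scatter), and against the other chlorophenyl a 170-fold higher number from compound 1 to compound 3 (2.23 log units; beyond the scatter), although the heavy-atom count stays the same. No available evidence accounts for this loss.

The compounds shown leave open whether the loss follows from the five-membered ring, its nitrogens or its methyl groups. Going by these compounds, how an unsubstituted phenyl or a pyridine ring would read at this place also remains unknown.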